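This account rests on a few compounds, and the source may have more. Where it says the series, first, only, none or still open, it means among the compounds named here.

The measured compounds:

Compound 1, `Cn1c(-c2ccccc2)c(Br)c(=O)[nH]c1=O`: in a functional assay on the whole organism for inhibition, with Rattus norvegicus as the target, at a dose of 50 mg/kg by the oral route (a lower number here means a weaker effect, a higher number a stronger effect of the compound at the dose given), compound 1 gives 43%.
Compound 2, `Cn1c(-c2ccccc2)c(I)c(=O)[nH]c1=O`: in this assay compound 2 gives 44%.
Compound 3, `Oc1nc(O)c(Br)c(-c2ccccc2)n1`: in this assay compound 3 gives 46%.

Compounds 1 and 2 share a core and differ in one place: iodo in place of bromo on an aromatic carbon. This change gave a number 1 percentage points higher from compound 1 to compound 2 (within the scatter), so the two halides cannot be told apart on this read-out. Compound 3 has a different core; the difference between the two cores is not broken down here. Its value stands alongside those of compound 1 and compound 2, all three within the usual scatter of one another, so none of them can be called stronger or weaker.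

Compound 4, `Oc1nc(O)c(I)c(-c2ccccc2)n1`, has not yet been measured. It differs from compound 3 by the same kind of change: iodo in place of bromo on an aromatic carbon. The surroundings of the place are not identical, though: in compound 4 the carbon is ortho to a hydroxy group and para to a hydroxy group, whereas in compound 2 it is ortho to a group of 1 heavy atom, meta to a methyl group and para to a group of 1 heavy atom.

Within the data shown here, the only guide is the one earlier step, which was flat. Compound 4 is therefore expected to show a number 1 percentage points higher from compound 3 to compound 4 (within the scatter), resting on the small step seen in a number 1 percentage points higher from compound 1 to compound 2 (within the scatter). The estimate for compound 4 in this assay is 47%, expected to fall between 35% and 59%.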

Compound 4, a percentage reported as inhibition, in the whole organism at one dose (the size of the read-out at that dose, not a potency): 41%
For compound 4 the middle estimate is 6 percentage points above the measured one; measured number inside the range.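

On the core of compound 3, iodo in place of bromo on an aromatic carbon gave a number 5 percentage points lower from compound 3 to compound 4 (within the scatter) in this assay, so on this core too the two halides cannot be told apart on this read-out. Set beside the step on the core of compound 1, this step does not differ from it: the same change on two cores in this assay, a number 1 percentage points higher (within the scatter) from compound 1 to compound 2 and a number 5 percentage points lower (within the scatter) from compound 3 to compound 4, 6 percentage points apart, within the scatter of two such steps. Within these two pairs the change therefore carries from one core to the other without a detectable dependence on the core, but this does not show that bromo and iodo are equivalent, as the read-out gives the size of the effect at a single dose rather than a potency, and a real difference smaller than the scatter would not appear in it.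

The compounds shown leave open whether anything other than these two halides on that carbon would move the read-out beyond the scatter, for instance a chloro group, an amine or a carboxylic acid. They also leave open what a longer chain in place of the methyl group on the core of compound 1 would do, and how much the difference between the two cores itself contributes to the read-out.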